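Fluoro on the benzyl ether of compound 1

A few compounds are considered here, and "the series" means these few. Any claim that something is new, unique, unknown or untested is made for them only; others in the source may bear on it.

Values in a functional assay on the whole organism with Mus musculus as the target (on this read-out lower numbers stand for an effect already at smaller amounts and higher numbers for an effect only at larger amounts of compound), as measured so far

- compound 1 `C[C@@H](NCc1ccc(OCc2ccccc2)cc1)C(N)=O` gives 23.8 mg/kg
- compound 2 `CNC(=O)[C@H](NCc1ccc(OCc2ccccc2)cc1)C(C)C` gives 112 mg/kg
- compound 3 `C[C@@H](NCc1ccc(Oc2ccccc2)cc1)C(N)=O` gives 64 mg/kg

Compound 1 stands lowest of the three numbers, with compound 3 nearest. Compound 4 `C[C@@H](NCc1ccc(OCc2ccc(F)cc2)cc1)C(N)=O` differs from compound 1 by fluoro in place of hydrogen on an aromatic carbon in the form of fluoro in place of hydrogen on an aromatic carbon, phenyl to 4-fluorophenyl. Among the measured compounds shown here, two measured steps bear on this only loosely: a 2.7-fold higher number from compound 1 to compound 3 (0.43 log units; beyond the scatter) on the oxygen substituent and a 4.7-fold higher number from compound 1 to compound 2 (0.67 log units; beyond the scatter) on the amine nitrogen. Both are modest, and neither is a fluoro change. No step beyond the scatter is therefore expected in this assay for this single replacement. The expected move is a 1.1-fold lower number from compound 1 to compound 4 (0.05 log units; within the scatter) and stays small. For compound 4 the estimated value is 21 mg/kg with an expected range from 10 mg/kg to 42 mg/kg in this read-out.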

Compound 4, dose for half-maximal effect: 132 mg/kg
For compound 4 the middle estimate is 6.3-fold (0.80 log units) below the measured one; measured number outside the range, above it.
By their numbers in this assay, from the lowest: compound 1; then compounds 3, 2 and 4 (each within the scatter of the next, the first and the last beyond it).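

In this assay the single replacement of hydrogen by fluoro, phenyl to 4-fluorophenyl, gives a 5.5-fold higher number from compound 1 to compound 4 (0.74 log units; beyond the scatter) and shows that this position on the benzyl ether is sensitive to one added heavy atom. The earlier steps shown here changed the substituents on the amine nitrogen and the oxygen, whereas here both stay as in compound 1 and the terminal phenyl alone changes. Nothing available accounts for this step.
From the compounds shown here alone, whether the same position tolerates a methoxy group, a chloro group or a methyl group stays open. Also open, going by these compounds, is whether a hydroxyl group there would behave as fluoro does.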